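A few compounds are considered here, and "the series" means these few. Any claim that something is new, unique, unknown or untested is made for them only; others in the source may bear on it.

Compound 1, with structure `O=C(O)CCCC/C=C(\c1cccnc1)c1ccsc1`, was tested in an assay (Equus caballus) for inhibition of Thromboxane-A synthase (Homo sapiens), using microsomes (a higher number here means a weaker inhibitor, a lower number a stronger inhibitor), where compound 1 gives 31 nM. Among the three measured compounds this is the second highest number. Compound 2, with structure `CC(C)(CCC/C=C(/c1ccccc1)c1cccnc1)C(=O)O`, gives 30 nM, a number within the scatter of compound 1. Compound 3, with structure `O=C(O)CCCC/C=C(/CCCc1ccccc1)c1cccnc1`, gives 65 nM, a higher number beyond the scatter. Compound 4, with structure `O=C(O)CCCC/C=C(\c1cccnc1)c1ccccc1Br`, has not yet been measured in this assay. Compound 4 differs from compound 1 by 2-bromophenyl in place of thiophen-3-yl on a double-bonded chain carbon bound to an aromatic carbon and a double-bonded chain carbon. Going by the values given here, no measured pair isolates this exchange, so its effect is uncertain; a modest step toward a higher number, or none beyond the scatter, is expected. Compound 4 is therefore estimated at 45 nM, with a range from 15 nM to 140 nM, an expected step of a 1.5-fold higher number from compound 1 to compound 4 (0.16 log units; within the scatter).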

Compound 4, half-maximal inhibitory concentration: 130 nM
Compound 4: the middle estimate sits 2.9-fold (0.46 log units) below what was measured; the measured number falls inside the stated range.
By their numbers in this assay, from the lowest: compounds 2 and 1 (each within the scatter of the next); then compounds 3 and 4 (each within the scatter of the next).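

In this assay, replacing thiophen-3-yl with 2-bromophenyl on this double-bonded chain carbon gives a 4.2-fold higher number from compound 1 to compound 4 (0.62 log units; beyond the scatter) and shows that the number responds to the group held at this place. The exchange changes the ring and adds a bromine together, and this single step does not separate the two. Nothing measured here accounts for the step. Open, on these data alone, is which part of the exchange carries the step, and how a 2-chlorophenyl or a thiophen-2-yl at this place would compare with compound 1.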